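The source may hold more compounds than are shown below. What is called first, only, known or untested is meant among the compounds shown, and "the series" means these compounds.

The measured compounds and their numbers:
compound 1 `CS(=O)(=O)CCNC(=O)Nc1cc2c(Nc3ccc(F)c(Cl)c3)ncnc2cc1O[C@H]1CCOC1` gives 1570 nM
compound 2 `CN(C)CCNC(=O)Nc1cc2c(Nc3ccc(F)c(Cl)c3)ncnc2cc1O[C@H]1CCOC1` gives 806 nM
compound 3 `CN(C)CCCNC(=O)Nc1cc2c(Nc3ccc(F)c(Cl)c3)ncnc2cc1O[C@H]1CCOC1` gives 226 nM

All three were tested in a functional assay on A-431 cells (Homo sapiens) for antiproliferative activity, read by sulforhodamine B assay, with a stated time of 72 h; a lower number here means a stronger inhibitor, a higher number a weaker inhibitor. Compound 1 has the highest number of the three. The step of a 1.9-fold lower number from compound 1 to compound 2 (0.29 log units; within the scatter) is within the scatter, whereas the step of a 6.9-fold lower number from compound 1 to compound 3 (0.84 log units; beyond the scatter) lies beyond it, as does the step of a 3.6-fold lower number from compound 2 to compound 3 (0.55 log units; beyond the scatter).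

Compound 4 `CN(C)CCCN(C)C(=O)Nc1cc2c(Nc3ccc(F)c(Cl)c3)ncnc2cc1O[C@H]1CCOC1` has not yet been measured. Relative to compound 1 the change is (3-(dimethylamino)propyl)(methyl)amino in place of (2-(methylsulfonyl)ethyl)amino on a carbonyl carbon. Within the data shown here, two measured steps bear on this. The first, a 6.9-fold lower number from compound 1 to compound 3 (0.84 log units; beyond the scatter), covers the replacement of the methylsulfonyl group by the (dimethylamino)methyl group on the chain; the second, a 3.6-fold lower number from compound 2 to compound 3 (0.55 log units; beyond the scatter), shows how much of that came from the longer chain alone. Among the measured compounds shown here, compound 4 carries the same 3-(dimethylamino)propyl chain as compound 3 but also a methyl on the amide-type nitrogen, a change for which no measured step exists. The expectation is therefore a lowering of the number of roughly the size seen from compound 1 to compound 3, with a wider range to allow for the extra methyl, namely a 5.2-fold lower number from compound 1 to compound 4 (0.72 log units; beyond the scatter). Compound 4 is thus expected to give about 300 nM, estimated between 110 nM and 900 nM.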

Compound 4, half-maximal inhibitory concentration: 200 nM
For compound 4 the middle estimate is 1.5-fold (0.18 log units) above the measured one; low and high end bracket the measured number.
By their numbers in this assay, from the lowest: compounds 4 and 3 (each within the scatter of the next); then compounds 2 and 1 (each within the scatter of the next).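

In this assay, among these compounds, methyl in place of hydrogen on the amide-type nitrogen gives a 1.1-fold lower number from compound 3 to compound 4 (0.05 log units; within the scatter), so this nitrogen tolerates the methyl, and its hydrogen, which the earlier compounds all kept, is not needed to hold the activity seen for compound 3. The full exchange on the carbonyl carbon stays beyond the scatter with the methyl in place, at a 7.9-fold lower number from compound 1 to compound 4 (0.89 log units; beyond the scatter) against the methylsulfonyl chain and a 4.0-fold lower number from compound 2 to compound 4 (0.61 log units; beyond the scatter) against the shorter (2-(dimethylamino)ethyl)amino group, so the gain linked to the 3-(dimethylamino)propyl chain survives the loss of that hydrogen in these compounds. No measurement shown here accounts for the size of any of these steps.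

On these data alone, whether the same methyl would be tolerated on the shorter chain of compound 2 or the methylsulfonyl chain of compound 1 remains open, so this result belongs to the 3-(dimethylamino)propyl chain alone. Also open, as far as these compounds go, is how this position would respond to something larger than methyl on the nitrogen, such as an ethyl group, to a longer chain such as 4-(dimethylamino)butyl, or to a ring amine such as morpholine at the chain end.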